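Chloro in Place of Phenyl on a Weak Hydroxamate-free Inhibitor

The compounds below may be only part of what the source reports. "The series", "measured", "known", "first", "only" and "open" are said of these compounds alone.

Compound 2 `O=C(CCCCCCNC(=O)C(O)(O)C(F)(F)F)Nc1ccc(-c2ccccc2)cc1` gives 1100000 nM in an assay on isolated protein for inhibition of histone deacetylase 4 (Homo sapiens), read by chemiluminescence, with a stated time of 3 h; a lower number here means a stronger inhibitor, a higher number a weaker inhibitor. Within the data shown here, of the two numbers so far it holds the lowest; its nearest neighbour is compound 1 `COc1ccc(NC(=O)CCCCCCNC(=O)C(O)(O)C(F)(F)F)cc1`, which gives 1600000 nM in this assay, a gap within the scatter. Among the measured compounds shown here, the only measured step, a 1.5-fold lower number from compound 1 to compound 2 (0.16 log units; within the scatter), came with phenyl in place of methoxy on an aromatic carbon and did not move the number beyond the scatter.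

Compound 3 `O=C(CCCCCCNC(=O)C(O)(O)C(F)(F)F)Nc1ccc(Cl)cc1` differs from compound 2 in one place: chloro in place of phenyl on an aromatic carbon. For the measured compounds named here, no measured step involves a chloro group, so the step between compounds 1 and 2 bears on it only by showing that exchanging groups on this aromatic carbon so far left the number within the scatter. A step of that kind, not beyond the scatter, is expected here too.

Compound 3 is therefore estimated to give about 1300000 nM in this assay, expected to fall between 500000 nM and 3500000 nM. This estimate is expected to amount to a 1.2-fold higher number from compound 2 to compound 3 (0.07 log units; within the scatter).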

Compound 3, half-maximal inhibitory concentration: 2700000 nM
The estimate for compound 3 lay 2.1-fold (0.32 log units) below the measured number; low and high end bracket the measured number.
By their numbers in this assay, from the lowest: compounds 2, 1 and 3 (each within the scatter of the next, the first and the last beyond it).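

Among these compounds, compound 3 gives the first step on this aromatic carbon to pass beyond the scatter in this assay, with a 2.5-fold higher number from compound 2 to compound 3 (0.39 log units; beyond the scatter) when chloro takes the place of phenyl. Chloro in place of methoxy gives a 1.7-fold higher number from compound 1 to compound 3 (0.23 log units; within the scatter) and stays within the scatter, so only chloro and phenyl are separated here, and methoxy stands apart from neither of them. Nothing available accounts for the step from phenyl to chloro.

The compounds shown leave open whether an amine or a carboxylic acid on this aromatic carbon would bring the number outside the range these three span. They also leave open whether a longer chain in the shared core would change how much the group on this carbon matters.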